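Hydroxymethyl to Carboxy on a Shared Pyrazole Warhead Scaffold

A few compounds are considered here, and "the series" means these few. Any claim that something is new, unique, unknown or untested is made for them only; others in the source may bear on it.

Measured compounds:
compound 1 `O=C(CCl)Nc1ccc(Cn2nc(-c3ccc(Oc4ccccc4)cc3)cc2CO)cc1` gives 400 nM
compound 2 `C/C=C/C(=O)Nc1cccc(Cn2nc(-c3ccc(Oc4ccccc4)cc3)cc2C(=O)O)c1` gives 24100 nM
compound 3 `C/C=C/C(=O)Nc1cccc(Cn2nc(-c3ccc(Oc4ccccc4)cc3)cc2CO)c1` gives 5700 nM

The three measured compounds were tested in a functional assay on Z-138 cells (Homo sapiens) for inhibition, read by luminescence and CellTiter-Glo, with a stated time of 72 h; a higher number here means a weaker inhibitor, a lower number a stronger inhibitor. Compound 1 gives the lowest number of the three, compound 3 sits next to it, and compound 2 gives the highest number. Compound 1 and compound 3 share much of their structure, but the difference between the two cores is not broken down here.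

Within the pair of compound 3 and compound 2 the change is a single one: carboxy in place of hydroxymethyl on an aromatic carbon. It produced a 4.2-fold higher number from compound 3 to compound 2 (0.63 log units; beyond the scatter). The same kind of change is now applied to compound 1 to give compound 4 `O=C(CCl)Nc1ccc(Cn2nc(-c3ccc(Oc4ccccc4)cc3)cc2C(=O)O)cc1`: carboxy in place of hydroxymethyl on an aromatic carbon. The two place descriptions are the same word for word, so the group is exchanged at the same position of the shared five-membered ring in both pairs.

Within the data shown here, with only one measured instance of this change, the account expects the step from compound 1 to compound 4 in this assay to be of a similar size, a 4.3-fold higher number from compound 1 to compound 4 (0.63 log units; beyond the scatter), resting on the step seen from compound 3 to compound 2 (a 4.2-fold higher number from compound 3 to compound 2 (0.63 log units; beyond the scatter)). On that basis compound 4 is estimated at 1700 nM, with the likely range running from 700 nM to 4500 nM. Among the measured compounds shown here, only one prior example of this change exists. The range is therefore kept wide.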

Compound 4, half-maximal inhibitory concentration: 1500 nM
Estimate against measurement, compound 4: 1.1-fold (0.05 log units) above, within the range that was stated.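

In this assay, placing carboxy where hydroxymethyl stood on the core of compound 1 gives a 3.8-fold higher number from compound 1 to compound 4 (0.57 log units; beyond the scatter), and this step matches the one seen earlier on the other core: the same change on two cores in this assay, a 4.2-fold higher number (0.63 log units; beyond the scatter) from compound 3 to compound 2 and a 3.8-fold higher number (0.57 log units; beyond the scatter) from compound 1 to compound 4, 1.1-fold (0.05 log units) apart, within the scatter of two such steps

Across these two cores, then, the change carries over in the same direction and at much the same size, so the step measured on one core would have served as a fair guide to the step on the other. Among these compounds, this rests on only two pairs in a single cell assay, however, so it does not establish a rule for the series, does not show that the step would hold on a third core, and says nothing about why the number rises when carboxy enters.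

The compounds shown leave open how other groups at this same ring carbon would read on either core, such as an amine, a primary amide or a methyl ester in place of hydroxymethyl. They also leave open whether the step would keep its size with a different group on the anilide nitrogen, such as a plain acetyl or an acrylamide.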